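The source may report more compounds than this note shows. Statements on the series, on what has been measured and on what is new or still open speak of the compounds shown alone.

Compound 1, `CC(C)COc1cccc(-c2ccc(C(=O)N(Cc3cccc(OCCCCCC(=O)O)c3)C(C)C)cc2)c1`, gives in an ADME assay on HEK293 cells (Homo sapiens) for cytotoxicity, read by CellTiter-Glo and resazurin assay, with a stated time of 72 h (a higher number here means that more compound is needed for the effect, a lower number that less compound is needed), a value of > 26000 nM, which is a limit of the assay rather than a number.
Compound 2, `CC(C)N(Cc1cccc(OCCCCCC(=O)O)c1)C(=O)c1ccc(-c2c[nH]c3ccccc23)cc1`, gives in this assay a value of > 26000 nM, again a limit.
Compound 3, `CCOC(=O)CCCCCOc1cccc(CN(C(=O)c2ccc(-c3cccc(OCC(C)C)c3)cc2)C(C)C)c1`, gives in this assay a value of > 26000 nM, also a limit.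

All three measured compounds thus sit at the same limit, as the limit of > 26000 nM in this assay, at which 3 of the 3 values shown sit, records, and compound 3 stands together with the other two at that limit. The step that the two limits leave unreadable from compound 1 to compound 2 cannot be read in size, and the same holds for a step that the two limits leave unreadable from compound 1 to compound 3. Compound 4, `CCOC(=O)CCCCCOc1cccc(CN(C(=O)c2ccc(-c3cccc(S(C)(=O)=O)c3)cc2)C(C)C)c1`, differs from compound 3 by methylsulfonyl in place of isobutoxy on an aromatic carbon. Going by the values given here, no measured step involves a methylsulfonyl group, so none bears directly on this change. Among the compounds with values here, the only guide is that every measured compound reached the limit without a readable effect. It is therefore expected that compound 4 also shows no cytotoxic effect within the measured range, with an estimated step that the limit leaves unreadable from compound 3 to compound 4 of no size beyond the scatter. The estimate for compound 4 in this assay is 40000 nM, ranging from 20000 nM to 100000 nM.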

Compound 4, half-maximal effective concentration: > 26000 nM
Compound 4: no number, only a limit; the forecaster's own chance of this, stated with the estimate: 90%; the middle value does not contradict the limit.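

Compound 4, like compound 3, gives only a limit and not a number in this assay, so the step between them cannot be read in size: the limit of > 26000 nM in this assay, at which 4 of the 4 values shown sit.

The compounds shown leave open at what concentration, if any, any of them would harm these cells, and so whether swapping isobutoxy for methylsulfonyl changes anything here.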